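Amidine to imidazoline swap across two fused-core isomers

The source may report more compounds than this note shows. Statements on the series, on what has been measured and on what is new or still open speak of the compounds shown alone.

Compound 1 `CC(C)NC(=N)c1ccc2oc(-c3cccc(OCCCCOc4ccccc4)c3)cc2c1` is the reference point: in an ADME assay on L6 cells (Rattus norvegicus) for cytotoxicity, read by resazurin assay, with a stated time of 70 h (a lower number here means a stronger inhibitor, a higher number a weaker inhibitor), compound 1 gives 36500 nM. Compound 2 `c1ccc(OCCCCOc2cccc(-c3cc4cc(C5=NCCN5)ccc4o3)c2)cc1` differs from it in one place, (a group of 5 heavy atoms (3 carbon, 2 nitrogen; one five-membered non-aromatic ring with 2 hetero atoms) in place of a group of 6 heavy atoms (4 carbon, 2 nitrogen; no ring), on an aromatic carbon), and in this assay compound 2 gives 9500 nM; the step was a 3.8-fold lower number from compound 1 to compound 2 (0.58 log units; beyond the scatter), a modest move beyond the scatter.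

Compound 3 `CC(C)NC(=N)c1ccc2cc(-c3cccc(OCCCCOc4ccccc4)c3)oc2c1` carries the same atoms as compound 1 joined differently; the difference between the two cores is not broken down here. In this assay compound 3 gives 46500 nM, which sits within the scatter of compound 1 and well away from compound 2.

Compound 4 `c1ccc(OCCCCOc2cccc(-c3cc4ccc(C5=NCCN5)cc4o3)c2)cc1` has not yet been measured. It stands to compound 3 as compound 2 stands to compound 1: the change is a group of 5 heavy atoms (3 carbon, 2 nitrogen; one five-membered non-aromatic ring with 2 hetero atoms) in place of a group of 6 heavy atoms (4 carbon, 2 nitrogen; no ring), on an aromatic carbon, the same change at the same kind of place. Among the compounds with values here, with only one earlier instance of this swap, the expectation is that the step will be of a similar size, a 3.6-fold lower number from compound 3 to compound 4 (0.55 log units; beyond the scatter). This rests on the step of a 3.8-fold lower number from compound 1 to compound 2 (0.58 log units; beyond the scatter). On that basis the estimate for compound 4 in this assay is 13000 nM, with a range from 6000 nM to 28000 nM.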

Compound 4, half-maximal inhibitory concentration: 5800 nM
For compound 4 the middle estimate is 2.2-fold (0.35 log units) above the measured one; the measured number lies below the stated range.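

In this assay the amidine to imidazoline swap lowers the number on the second core as well, an 8.0-fold lower number from compound 3 to compound 4 (0.90 log units; beyond the scatter), so the direction seen on the core of compound 1 carries over to the core of compound 3. The size of the step also carries over as far as these data can tell, as the two steps cannot be told apart: the same change on two cores in this assay, a 3.8-fold lower number (0.58 log units; beyond the scatter) from compound 1 to compound 2 and an 8.0-fold lower number (0.90 log units; beyond the scatter) from compound 3 to compound 4, 2.1-fold (0.32 log units) apart, within the scatter of two such steps

Within the data shown here, this is only one pair of cores in a single assay, and it does not show that the step would hold on any further core or say what lies behind it.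

Still open, as far as these compounds go, is how other groups on the same aromatic carbon would behave, such as an unsubstituted amidine, a primary amine or a tetrahydropyrimidine ring. Also open is whether the swap keeps its direction with a shorter or longer chain in place of the one shared by all the compounds shown.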